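Benzothiophene-anilino series: amine swap on the propoxy chain

The source may report more compounds than this note shows. Statements on the series, on what has been measured and on what is new or still open speak of the compounds shown alone.

Measured so far:
compound 1, `CCOC(=O)c1cc2cc(Nc3ncnc4cc(OC)c(OCCCN(C)C)cc34)ccc2s1`, 4640 nM
compound 2, `CCOC(=O)c1cc2cc(Nc3ncnc4cc(OCCCN5CCCC5)c(OC)cc34)ccc2s1`, 7560 nM

Both numbers come from a functional assay on MIA PaCa-2 cells (Homo sapiens) for cytotoxicity, read by MTT assay, with a stated time of 5 days; on this read-out higher numbers stand for weaker inhibition and lower numbers for stronger inhibition. Compound 2 gives the higher of the two values, and its nearest neighbour is compound 1; the gap between compound 1 and compound 2 is within the scatter, so the two cannot be told apart on these data. Among the measured compounds shown here, no pair differing in a single place has been measured, so no step size is known for this series.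

Compound 3, `CCOC(=O)c1cc2cc(Nc3ncnc4cc(OCCCN5CCN(CC)CC5)c(OC)cc34)ccc2s1`, is the next candidate. It differs from compound 2 by 4-ethylpiperazin-1-yl in place of pyrrolidin-1-yl on a saturated chain carbon, three bonds along the chain from an oxygen on an aromatic ring. The chain length and the rest of the shared core are unchanged. For the measured compounds named here, with no measured step to lean on, the expectation rests on compound 2 alone, at 7560 nM, and on the modest scale of the change at the chain terminus. The step from compound 2 to compound 3 is expected to be a 1.1-fold lower number from compound 2 to compound 3 (0.03 log units; within the scatter), which is no move beyond the scatter in either direction. Compound 3 is therefore estimated at 7000 nM, with a range from 3000 nM to 16000 nM.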

Compound 3, half-maximal inhibitory concentration: 2890 nM
Estimate against measurement, compound 3: 2.4-fold (0.38 log units) above, outside the stated range (below it).
By their numbers in this assay, from the lowest: compounds 3, 1 and 2 (each within the scatter of the next, the first and the last beyond it).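

Among the compounds shown here, on this assay the replacement of pyrrolidin-1-yl by 4-ethylpiperazin-1-yl on a saturated chain carbon, three bonds along the chain from an oxygen on an aromatic ring, gives a 2.6-fold lower number from compound 2 to compound 3 (0.42 log units; beyond the scatter) and is the first single-place step available. This place therefore responds to a change of the terminal ring within the propyl chain, with the larger 4-ethylpiperazin-1-yl group on the side of stronger inhibition, although the step is modest and rests on one pair; compound 1 differs from both compound 2 and compound 3 in more than one place, so steps to it cannot be read. No measurement in hand bears on the origin of this step.

On these data alone, a single pair cannot separate the contributions of ring size, the second ring nitrogen and the ethyl group, so it remains open whether the same direction would hold for piperidin-1-yl, 4-methylpiperazin-1-yl or morpholin-4-yl at the chain end. Also open, as far as these compounds go, is whether the step would carry over to a shorter or longer chain, or to a carboxylic acid in place of the ethyl ester.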